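The compounds below may be only part of what the source reports. "The series", "measured", "known", "first", "only" and "open" are said of these compounds alone.

Measured compounds:
- compound 1, `CC/C=C/Cn1c(Cc2cc(OC)c(OC)c(OC)c2)nc2c(N)ncnc21`: 46800 nM
- compound 2, `CCn1c(Cc2cc(OC)c(OC)c(OC)c2)nc2c(N)ncnc21`: 79400 nM
- compound 3, `CCCCCn1c(Cc2cc(OC)c(OC)c(OC)c2)nc2c(N)ncnc21`: 61700 nM

All three share one core and differ only in the chain on the aromatic nitrogen. In a functional assay on MCF7 cells (Homo sapiens) for antiproliferative activity (on this read-out lower numbers stand for stronger inhibition and higher numbers for weaker inhibition), compound 3 gives 61700 nM, the second highest of the three numbers. Its nearest neighbour is compound 2, with a 1.3-fold lower number from compound 2 to compound 3 (0.11 log units; within the scatter); its furthest is compound 1, with a 1.3-fold higher number from compound 1 to compound 3 (0.12 log units; within the scatter). Neither of these steps stands apart from the scatter of the measurement.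

Compound 4, `CCC(C)Cn1c(Cc2cc(OC)c(OC)c(OC)c2)nc2c(N)ncnc21`, is not yet measured. It differs from compound 3 in one place: sec-butyl in place of butyl on a saturated chain carbon bound to an aromatic nitrogen. Every earlier step also changed the chain on this nitrogen, and each stayed within the scatter: a 1.7-fold higher number from compound 1 to compound 2 (0.23 log units; within the scatter), a 1.3-fold higher number from compound 1 to compound 3 (0.12 log units; within the scatter) and a 1.3-fold lower number from compound 2 to compound 3 (0.11 log units; within the scatter). Rearranging the same four carbons of the chain is a smaller change than any of those, so in this assay no step beyond the scatter is expected, in either direction.

The expected step is a 1.0-fold lower number from compound 3 to compound 4 (0.01 log units; within the scatter). For compound 4 the estimate in this assay is 60000 nM, within a range from 30000 nM to 120000 nM.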

Compound 4, half-maximal inhibitory concentration: 61700 nM
For compound 4 the middle estimate is 1.0-fold (0.01 log units) below the measured one; the measured number falls inside the stated range.
By their numbers in this assay, from the lowest: compounds 1, 3, 4 and 2 (each within the scatter of the next).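

Sec-butyl is the first chain in this set to carry a branch, and in this assay, putting it in place of butyl on a saturated chain carbon bound to an aromatic nitrogen gives no change at the digits printed from compound 3 to compound 4 (within the scatter). The branched chain also sits close to the other two chains, with a 1.3-fold lower number from compound 2 to compound 4 (0.11 log units; within the scatter) for sec-butyl in place of methyl and a 1.3-fold higher number from compound 1 to compound 4 (0.12 log units; within the scatter) for sec-butyl in place of but-1-en-1-yl, so among the four compounds shown, neither the length of the chain, nor its double bond, nor this branch gives a step beyond the scatter. Nothing available explains why this position tolerates these chains so evenly.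

Still open, going by these compounds, is whether a chain ending in an amine or a carboxylic acid, a benzyl group, or a much longer chain such as dodecyl would give a step beyond the scatter at this place. All four compounds also share the same core, so they say nothing about how changes elsewhere in that core would affect the number.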